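Replacing the methylphenyl arm in a bicyclic lactam series

The source may hold more compounds than are shown below. What is called first, only, known or untested is meant among the compounds shown, and "the series" means these compounds.

Compound 2 `Cc1cccc(C#Cc2ccc3c(n2)CCN(C2CCCCC2)C3=O)c1` was tested in an assay on HEK293 cells for displacement of a labelled ligand from metabotropic glutamate receptor 5 (Homo sapiens), with a stated time of 2 h (on this read-out higher numbers stand for weaker inhibition and lower numbers for stronger inhibition), where it gives 3210 nM. Its only measured companion, compound 1 `CN1CCc2nc(C#Cc3ccccn3)ccc2C1=O`, gives 6240 nM in this assay, and the two numbers lie within the usual scatter of each other, so neither can be called the stronger. Compound 3 `O=C1c2ccc(C#Cc3ccccn3)nc2CCN1C1CCCCC1` has not yet been measured. It differs from compound 2 by pyridin-2-yl in place of 3-methylphenyl on a triple-bonded carbon. Going by the values given here, no measured pair shows this exchange on its own, so the size of the step is open; the step from compound 2 to compound 3 is expected to be modest, a 1.6-fold higher number from compound 2 to compound 3 (0.19 log units; within the scatter), and towards a weaker read-out. Compound 3 is therefore estimated at 5000 nM, with a range from 1500 nM to 16000 nM.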

Compound 3, inhibition constant: 2240 nM
The estimate for compound 3 lay 2.2-fold (0.35 log units) above the measured number; the range from low to high includes it.
By their numbers in this assay, from the lowest: compounds 3, 2 and 1 (each within the scatter of the next, the first and the last beyond it).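

In this assay, pyridin-2-yl in place of 3-methylphenyl on a triple-bonded carbon gives a 1.4-fold lower number from compound 2 to compound 3 (0.16 log units; within the scatter), so this arm can be exchanged without a change that can be resolved in this read-out. Going by these compounds alone, with pyridin-2-yl held constant, cyclohexyl in place of methyl on the amide-type nitrogen gives a 2.8-fold lower number from compound 1 to compound 3 (0.44 log units; beyond the scatter), the only step here beyond the scatter. No supporting measurement accounts for either step. As far as these compounds go, whether a pyrimidine or thiazole ring on the triple-bonded carbon would separate from compound 3 remains open. So does the effect of an isopropyl or phenyl group on that nitrogen.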